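The compounds below may be only part of what the source reports. "The series", "measured", "known", "first", "only" and "open" are said of these compounds alone.

Compound 1, with the structure `Cc1ccc(OCC(=O)N(Cc2cccs2)c2ccn(C)n2)cc1`, is the weakest of the three measured compounds in an assay on HEK293 cells for agonist activity at transient receptor potential cation channel subfamily M member 8 (Homo sapiens), read by fluorescence and calcium flux, with a stated time of 15 min (a higher number here means that more compound is needed for the effect, a lower number that less compound is needed), where it gives 855 nM. Compound 2, with the structure `CCN(Cc1cccs1)C(=O)COc1ccc2c(c1)COC2`, reaches 61 nM in this assay, and compound 3, with the structure `COc1ccc2oc(C(=O)N(Cc3cccs3)c3ccn[nH]3)cc2c1`, gives 1.1 nM, so compound 1 sits well behind both, by margins clearly beyond the usual scatter.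

Compound 4, with the structure `COCCN(Cc1cccs1)C(=O)COc1ccc(C)cc1`, has not yet been measured. It differs from compound 1 in one place: 2-methoxyethyl in place of 1-methyl-1H-pyrazol-3-yl on an amide-type nitrogen. The group that leaves carries a five-membered aromatic ring, while the group that enters is an open chain.

Among the measured compounds, compound 2 shows that a small saturated group on the amide-type nitrogen can go together with a low number, 61 nM, though its other half also differs from compound 1. A modest drop in the number is expected from compound 1 to compound 4, a 1.7-fold lower number from compound 1 to compound 4 (0.23 log units; within the scatter), possibly no larger than the scatter. Compound 4 is estimated at 500 nM in this assay, within the range 100 nM to 2500 nM.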

Compound 4, half-maximal effective concentration: 400 nM
Estimate against measurement, compound 4: 1.3-fold (0.10 log units) above, and the stated range covers the measured number.
By their numbers in this assay, from the lowest: compound 3; then compound 2; then compound 4; then compound 1.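

For the compounds shown here, compound 1 and compound 4 differ only in the group on the amide-type nitrogen, so this pair isolates that position, which the earlier compounds could not do because they differ from one another in more than one place. In this assay, replacing 1-methyl-1H-pyrazol-3-yl with 2-methoxyethyl gives a 2.1-fold lower number from compound 1 to compound 4 (0.33 log units; beyond the scatter), so in this pair the five-membered aromatic ring is not needed to keep agonist activity, and an open chain serves slightly better. No measurement here explains this modest shift.

From the compounds shown here alone, it remains open whether the oxygen in the chain matters, which a plain butyl chain on the same nitrogen of the core of compound 1 could show. Going by these compounds, how a longer chain ending in a hydroxyl group or an amine would compare also remains unknown.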